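The source may hold more compounds than are shown below. What is called first, only, known or untested is meant among the compounds shown, and "the series" means these compounds.

Measured so far:
compound 1 `CCC1=C(O)c2c(oc(-c3ccc(C)cc3)cc2=O)C(CC)(CC)C1=O`: 39.2 uM
compound 2 `CCCc1ccc(-c2cc(=O)c3c(o2)C(CC)(CC)C(=O)C(CC)=C3O)cc1`: > 53 uM (a limit, not a number)
compound 3 `CCC1=C(O)c2c(oc(-c3ccc(OC(F)(F)F)cc3)cc2=O)C(CC)(CC)C1=O`: 36.5 uM

In a functional assay on KB cells (Homo sapiens) for antiproliferative activity, read by sulforhodamine B assay, with a stated time of 3 days (on this read-out higher numbers stand for an effect only at larger amounts of compound and lower numbers for an effect already at smaller amounts), compound 3 gives 36.5 uM and compound 1 gives 39.2 uM. These two values lie within the scatter of each other, so neither can be placed ahead of the other. Compound 2 gives > 53 uM, which is a limit of this assay and not a number.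

The next compound, compound 4 `CCC1=C(O)c2c(oc(-c3ccc(CBr)cc3)cc2=O)C(CC)(CC)C1=O`, carries bromomethyl in place of trifluoromethoxy on an aromatic carbon, para to a large group: bromomethyl in place of trifluoromethoxy on an aromatic carbon.

Going by the values given here, three measured steps bear on this change. Two replace the group at this same place: a 1.1-fold lower number from compound 1 to compound 3 (0.03 log units; within the scatter) and an at least 1.4-fold lower number from compound 2 to compound 3 (0.16 log units; that floor lies within the scatter). The third changes the chain of that group: an at least 1.3-fold higher number from compound 1 to compound 2 (0.13 log units; that floor lies within the scatter). None of them is shown beyond the scatter, although two of them rest only on a floor. Bromomethyl itself has not been measured in this series, so the expectation rests on these steps alone, and no shift beyond the scatter is foreseen. The expected step is a 1.2-fold lower number from compound 3 to compound 4 (0.09 log units; within the scatter), which stays within the scatter. For compound 4 the estimated value is 30 uM, with an expected range from 12 uM to 55 uM.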

Compound 4, concentration for half-maximal effect: > 46.5 uM
Compound 4: no number, only a limit; the forecaster's own chance of this, stated with the estimate: 20%; middle value at least 1.5-fold (0.19 log units) from the limit.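

In this assay compound 4 gives > 46.5 uM, which is a limit of the assay and not a number. The readable steps are an at least 1.2-fold higher number from compound 3 to compound 4 (0.10 log units; that floor lies within the scatter) and an at least 1.1-fold higher number from compound 1 to compound 4 (0.07 log units; that floor lies within the scatter); both are floors only, so bromomethyl at this place on the aromatic carbon is not separated from trifluoromethoxy or methyl, yet this change adds no sign of a lower number. The step linking compound 4 to compound 2 cannot be read; compound 2 also ends in a limit, so a second group at this place gives no number: the limit of > 53 uM in this assay, at which 1 of the 4 values shown sits.

From the compounds shown here alone, the values behind the limits of compound 2 and compound 4 stay open, and with them any order among the four groups at this place. Also open, going by these compounds, is whether an aminomethyl group, a carboxylic acid or a hydroxymethyl group on this aromatic carbon would give a number that differs from those of compound 1 and compound 3 by more than the scatter.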